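From 3-fluorophenyl to 2,4-difluorophenyl

The source may hold more compounds than are shown below. What is called first, only, known or untested is meant among the compounds shown, and "the series" means these compounds.

In an ADME assay on HepG2 cells (Homo sapiens) for cytotoxicity, read by MTT assay, with a stated time of 72 h (a lower number here means that less compound is tolerated, a higher number that more compound is tolerated), compound 1 `O=[N+]([O-])c1c(CS(=O)(=O)c2ccccc2)nc2c(-c3ccccc3)cc(Cl)cn12` gives > 15600 nM, which is a limit and not an exact number. Compound 2 `COc1ccc(-c2cc(Cl)cn3c([N+](=O)[O-])c(CS(=O)(=O)c4ccccc4)nc23)cc1` gives > 3900 nM, which is also a limit. On these data alone, compound 3 `O=[N+]([O-])c1c(CS(=O)(=O)c2ccccc2)nc2c(-c3cccc(F)c3)cc(Cl)cn12` gives > 12500 nM, again a limit, so its true position remains open.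

Compound 4 `O=[N+]([O-])c1c(CS(=O)(=O)c2ccccc2)nc2c(-c3ccc(F)cc3F)cc(Cl)cn12` carries 2,4-difluorophenyl in place of 3-fluorophenyl on an aromatic carbon. The closest measured change, fluoro in place of hydrogen, is a step that the two limits leave unreadable from compound 1 to compound 3. Methoxy in place of hydrogen is a step that the two limits leave unreadable from compound 1 to compound 2. Exchanging 4-methoxyphenyl for 3-fluorophenyl is a step that the two limits leave unreadable from compound 2 to compound 3. None of these steps has a readable size, so they give no reason to expect a shift in either direction in this assay. The expected result is a number no higher from compound 3 to compound 4 (the limit leaves the size open), with no change anticipated beyond the scatter. Compound 4 is estimated at 12500 nM, with an expected range from 5000 nM to 30000 nM. It may well be reported only as a limit.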

Compound 4, half-maximal cytotoxic concentration: > 7800 nM
Compound 4 was reported as a limit; the forecaster's own chance of this, stated with the estimate: 85%; the middle value does not contradict the limit.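

Compound 4, like compound 1, compound 2 and compound 3, is reported in this assay only as a limit, so no step between any of these compounds can be read. On these data alone, whether phenyl, 3-fluorophenyl, 4-methoxyphenyl or 2,4-difluorophenyl changes how much compound the cells tolerate remains open.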